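Aryl ketone variation on a phenylthiazole acetamide series

The source may hold more compounds than are shown below. What is called first, only, known or untested is meant among the compounds shown, and "the series" means these compounds.

Measured so far in a functional assay on Ehrlich cells (Mus musculus) for cytotoxicity, read by trypan blue exclusion, with a stated time of 48 h; a higher number here means a weaker inhibitor, a lower number a stronger inhibitor:
compound 1 `Cc1cc(C(=O)c2ccc(F)cc2)ccc1OCC(=O)Nc1nc(-c2ccccc2)cs1` gives 35200 nM
compound 2 `Cc1cc(C(=O)c2cccc(Br)c2)ccc1OCC(=O)Nc1nc(-c2ccccc2)cs1` gives 24300 nM

Compound 2 has the lowest of the two numbers shown; its nearest neighbour is compound 1, and the step of a 1.4-fold lower number from compound 1 to compound 2 (0.16 log units; within the scatter) stays within the scatter. The next compound, compound 3 `Cc1cc(C(=O)c2ccccc2C)ccc1OCC(=O)Nc1nc(-c2ccccc2)cs1`, changes the aryl ketone again: 2-methylphenyl in place of 3-bromophenyl on a carbonyl carbon. Going by the values given here, the only measured step that bears on a change at this carbonyl is the one just named, and it was small. No step beyond the scatter is therefore expected from compound 2 to compound 3; the estimated step is a 1.2-fold higher number from compound 2 to compound 3 (0.06 log units; within the scatter). For compound 3 the estimate is 28000 nM, with a range from 12000 nM to 65000 nM.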

Compound 3, half-maximal inhibitory concentration: 24300 nM
Compound 3: the middle estimate sits 1.2-fold (0.06 log units) above what was measured, within the range that was stated.
By their numbers in this assay, from the lowest: compounds 2, 3 and 1 (each within the scatter of the next).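

At this carbonyl carbon in this assay, 2-methylphenyl replaces 3-bromophenyl with no change at the digits printed from compound 2 to compound 3 (within the scatter) and replaces 4-fluorophenyl with a 1.4-fold lower number from compound 1 to compound 3 (0.16 log units; within the scatter). The three aryl groups, now including one without halogen, cannot be told apart in this read-out. Nothing on hand offers a reason for this flat result. Still open, as far as these compounds go, is whether an aryl group carrying an amine or a carboxylic acid, or a cyclohexyl ring in place of the aryl group, would move the number beyond the scatter.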